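A Bulkier Sulfonyl Aryl Group on a Weak Binder

The source may hold more compounds than are shown below. What is called first, only, known or untested is meant among the compounds shown, and "the series" means these compounds.

Compound 2 `CC[C@H](C)[C@H](NC(=O)c1cccc(Cn2ccnc2)c1)C(=O)NNS(=O)(=O)c1ccc(C)cc1` carries a sulfonyl hydrazide bearing a 4-methylphenyl group. Among the compounds with values here, in an assay on HEK293 cells for displacement of a labelled ligand from Type-2 angiotensin II receptor (Homo sapiens), tested at 1 uM (on this read-out higher numbers stand for a stronger effect at the one concentration tested and lower numbers for a weaker effect), compound 2 gives 4%, a weak effect and the only number available, since compound 1 `CCCCS(=O)(=O)NNC(=O)[C@@H](NC(=O)c1cccc(Cn2ccnc2)c1)[C@@H](C)CC` has no result reported in this assay: "not determined" (no result reported). Compound 3 `CC[C@H](C)[C@H](NC(=O)c1cccc(Cn2ccnc2)c1)C(=O)NNS(=O)(=O)c1c(C)cc(C)cc1C` differs from compound 2 in one place: 2,4,6-trimethylphenyl in place of 4-methylphenyl on a sulfonyl sulfur. Within the data shown here, no step between measured compounds is known, so the expectation rests on compound 2 alone. The step expected is a number 2 percentage points higher from compound 2 to compound 3 (within the scatter), a change no larger than the usual scatter. Compound 3 is therefore estimated at 6%, within a range from -8% to 22%.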

Compound 3, a percentage reported as inhibition, at one concentration (the size of the read-out at that concentration, not a potency): 10%
Compound 3: the middle estimate sits 4 percentage points below what was measured; the range from low to high includes it.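

Going from 4-methylphenyl to 2,4,6-trimethylphenyl on a sulfonyl sulfur gives a number 6 percentage points higher from compound 2 to compound 3 (within the scatter) in this assay. This change of aryl group therefore does not separate the two compounds, and both remain weak at the one concentration tested. Nothing available explains this result or ties it to a property of either group.

Steps involving compound 1 cannot be read, so how its butyl chain compares with these aryl groups stays open. Also open, on these data alone, is whether an amine or a carboxylic acid on the aryl ring would move the effect beyond the scatter.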